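The source may hold more compounds than are shown below. What is called first, only, known or untested is meant among the compounds shown, and "the series" means these compounds.

Compound 1 `Clc1cccc2c1C=C(CC1CN=CN1)CC2` — 50.1 nM
Compound 2 `NC1=NCC(CC2=Cc3ccccc3CC2)O1` — 1000 nM
Compound 3 `C1=NC[C@@H](C2CC23Cc2ccccc2C3)N1` — 316 nM

These three compounds were each tested in a functional assay for binding affinity to Norepinephrine transporter (Rattus norvegicus), read by radioligand binding, in the presence of a further agent that is not named here; on this read-out higher numbers stand for weaker inhibition and lower numbers for stronger inhibition. Among them compound 3 stands with the second highest inhibition constant: compound 2 sits beyond the scatter on the weaker side, with a higher number, while compound 1 sits beyond the scatter on the stronger side, with a lower number. Compound 3 is thus neither the strongest nor the weakest of the three.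

The next compound, compound 4 `C1=NC[C@H](C2CC23Cc2ccccc2C3)N1`, keeps every atom and bond of compound 3. The difference is the two compounds have the same atoms and bonds; at least one stereo element is drawn with a configuration in one of them and without one in the other: 1 of 2 stereo elements differ; a stereocentre at a saturated ring carbon is drawn R in compound 3 and S in compound 4. Among the measured compounds shown here, no step of this kind between two measured compounds is available here, so there is no measured precedent to guide the direction. For such an inversion at a single ring carbon the account expects that the two forms may well separate, but on these data alone the direction cannot be read, and the expectation for the step from compound 3 to compound 4 in this assay is therefore no change at the digits printed from compound 3 to compound 4 (within the scatter), with a wide band on either side. Compound 4 is estimated at 316 nM, within the range 50 nM to 2000 nM.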

Compound 4, inhibition constant: 31.6 nM
Beside the measured number, compound 4's estimate is 10-fold (1.00 log units) above it; measured number below the stated range.
By their numbers in this assay, from the lowest: compounds 4 and 1 (each within the scatter of the next); then compound 3; then compound 2.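

In this assay, changing the drawn configuration at this saturated ring carbon from R to S, with no atom or bond altered, gives a 10-fold lower number from compound 3 to compound 4 (1.00 log units; beyond the scatter). Among the compounds shown here, this is the first step that isolates a single change, and it shows that the configuration at this one position can by itself shift the inhibition constant beyond the usual scatter, with the S form giving the stronger inhibition of this pair. One fact limits how cleanly the step can be read as a simple inversion at one carbon: the fact that one of compounds 3 and 4 is drawn with a defined configuration and the other without, at the place where they differ

The compounds shown leave open what part the other stereo element plays, and whether the preference for the S form at this carbon would hold in a related compound, such as one bearing the chlorine of compound 1 on the shared aromatic portion. They also leave open whether the same preference would survive if a methyl group or a hydroxyl group were placed on this ring carbon.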